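A few compounds are considered here, and "the series" means these few. Any claim that something is new, unique, unknown or untested is made for them only; others in the source may bear on it.

Series notes. Compound 1 `CC1(C)[C@H](Nc2cc(NCc3cnccc3C(F)(F)F)ncc2C#N)C[C@H]1C(N)=O` and compound 2 `CC1(C)[C@@H](Nc2cc(NCc3cnccc3C(F)(F)F)ncc2C#N)C[C@H]1C(N)=O` share every atom and bond and differ only in configuration as drawn. In an assay on isolated protein for inhibition of protein kinase C theta type (Homo sapiens), read by TR-FRET, with a stated time of 2 h (on this read-out higher numbers stand for weaker inhibition and lower numbers for stronger inhibition), compound 1 gives 140 nM, and in this assay compound 2 gives 140 nM. The step of no change at the digits printed from compound 1 to compound 2 (within the scatter) shows that inverting one stereocentre at a saturated ring carbon left the read-out where it was; the only thing that separates the pair is the fact that compounds 1 and 2 differ only in the configuration as drawn, so no cause is assigned. Compound 2 thus stands level with compound 1 at the digits shown.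

Compound 3 `CC1(C)[C@@H](Nc2cc(NCc3cnccc3C(F)(F)F)ncc2C#N)C[C@@H]1C(N)=O` is to be measured in this assay. Its change from compound 2 is the two compounds have the same atoms and bonds and differ only in configuration as drawn: 1 of 2 stereo elements differ; a stereocentre at a saturated ring carbon is drawn R in compound 2 and S in compound 3. Within the data shown here, the one measured step that bears on this kind of change is no change at the digits printed from compound 1 to compound 2 (within the scatter), which was flat, so a step of no size beyond the scatter is expected in this assay for compound 3, in no particular direction. The expected step is a 1.4-fold higher number from compound 2 to compound 3 (0.15 log units; within the scatter). Compound 3 is therefore estimated at 200 nM, with a range from 60 nM to 700 nM.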

Compound 3, half-maximal inhibitory concentration: 1100 nM
The estimate for compound 3 lay 5.5-fold (0.74 log units) below the measured number; measured number outside the range, above it.
By their numbers in this assay, from the lowest: compounds 1 and 2 (each within the scatter of the next); then compound 3.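

In this assay the series is not indifferent to configuration: a 7.9-fold higher number from compound 2 to compound 3 (0.90 log units; beyond the scatter), whereas inverting the other stereocentre had left the read-out flat. The mirror-image pair separates by the same margin, a 7.9-fold higher number from compound 1 to compound 3 (0.90 log units; beyond the scatter), so the response depends on which saturated ring carbon is inverted, at least across these three compounds. Nothing but configuration separates each of these pairs, so the shift can be put down to configuration alone: the fact that compounds 2 and 3 differ only in the configuration as drawn

The compounds shown leave open how the mirror image of compound 2 would read, and so whether the two stereocentres act independently or only in combination. They also leave open whether this sensitivity to configuration would persist with a carboxylic acid or a methyl ester in place of the carboxamide.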